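Chain extension at the sulfur: compound 3 to compound 4

The source may report more compounds than this note shows. Statements on the series, on what has been measured and on what is new or still open speak of the compounds shown alone.

Measured so far:
- compound 1 `CCSc1nnc(COc2cc(C)c3c(C)cc(=O)oc3c2)o1`, in a functional assay on MCF7 cells (Homo sapiens) for antiproliferative activity, read by MTT assay, with a stated time of 24 h (a lower number here means a stronger inhibitor, a higher number a weaker inhibitor), a limit of > 100000 nM
- compound 2 `CCCSc1nnc(COc2cc(C)c3c(C)cc(=O)oc3c2)o1`, in this assay a limit of > 100000 nM
- compound 3 `CCCCCSc1nnc(COc2cc(C)c3c(C)cc(=O)oc3c2)o1`, in this assay a limit of > 100000 nM

Compound 3 stands only at a limit in this assay, and all three measured values sit there (the limit of > 100000 nM in this assay, at which 3 of the 3 values shown sit). Compound 4 `CCCCCCSc1nnc(COc2cc(C)c3c(C)cc(=O)oc3c2)o1` differs from compound 3 by methyl in place of hydrogen on a saturated chain carbon, five bonds along the chain from a sulfur. Within the data shown here, the steps that bear on this change are a step that the two limits leave unreadable from compound 1 to compound 2, a step that the two limits leave unreadable from compound 1 to compound 3 and a step that the two limits leave unreadable from compound 2 to compound 3; none of them is readable in size, so no direction can be taken from them. Compound 4 is therefore expected to remain at the limit, which means a step that the limit leaves unreadable from compound 3 to compound 4 in this assay. Compound 4 is estimated at 150000 nM, with a range from 50000 nM to 500000 nM.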

Compound 4, half-maximal inhibitory concentration: > 100000 nM
Compound 4 ended at the assay's limit; the forecaster's own chance of this, stated with the estimate: 85%; the middle value does not contradict the limit.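

In this assay compound 4 gives > 100000 nM, which is a limit. Among these compounds, no step from compound 1, compound 2 or compound 3 to compound 4 can be read: the limit of > 100000 nM in this assay, at which 4 of the 4 values shown sit. The compounds shown leave open whether any chain length at the sulfur gives a measurable value in this assay.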